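From methoxy to methyl: what to expect of compound 3

The compounds below may be only part of what the source reports. "The series", "measured", "known", "first", "only" and "open" are said of these compounds alone.

In a functional assay on MT4 cells (Homo sapiens) for cytotoxicity (a higher number here means a weaker inhibitor, a lower number a stronger inhibitor), compound 1 `N#Cc1c(N)cccc1S(=O)(=O)c1ccccc1` gives > 5000 nM, which is a limit of the assay and not a number. Going by the values given here, compound 2 `COc1ccccc1S(=O)(=O)c1cccc(N)c1C#N` gives 146000 nM, the only true number so far, so it has no measured neighbour to be ranked against. Compound 3 `Cc1ccccc1S(=O)(=O)c1cccc(N)c1C#N` carries methyl in place of methoxy on an aromatic carbon, ortho to a large group: methyl in place of methoxy on an aromatic carbon. Among the compounds with values here, only one measured step bears on this position, a step that the limit leaves unreadable from compound 1 to compound 2, and it offers no size to build on. With no readable step as a guide, no change beyond the usual scatter is expected in this assay, and the expected shift is a 1.2-fold lower number from compound 2 to compound 3 (0.09 log units; within the scatter). The estimate for compound 3 is 120000 nM, expected to fall between 40000 nM and 300000 nM.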

Compound 3, half-maximal inhibitory concentration: > 200000 nM
Compound 3 was reported as a limit (the forecaster's own chance of this, stated with the estimate: 35%); middle value at least 1.6-fold (0.22 log units) from the limit.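

In this assay, methyl in place of methoxy on this aromatic carbon gives an at least 1.3-fold higher number from compound 2 to compound 3 (0.13 log units; that floor lies within the scatter). Compound 3 is reported only as a limit of the assay and not a number, so this step has a floor but no full size: the limit of > 200000 nM in this assay, at which 1 of the 3 values shown sits. Going by these compounds alone, this is the first step at this position with any readable size, although its floor does not show a change beyond the usual scatter, and the two steps from compound 1 cannot be read.

Going by these compounds, how far compound 3 truly lies from compound 2 stays open, as does whether methoxy matters at this position at all. An amine or a carboxylic acid on the same aromatic carbon, or a longer chain such as ethoxy, would show whether any group here moves the number beyond the scatter.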